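Swapping a butylamino for a diethylamino on a benzylic carbon

The source may report more compounds than this note shows. Statements on the series, on what has been measured and on what is new or still open speak of the compounds shown alone.

Measured so far in a functional assay on HEK293 cells for agonist activity at 5-hydroxytryptamine receptor 7 (Homo sapiens), read by a luciferase reporter and beta-arrestin recruitment, with a stated time of 22 h; on this read-out higher numbers stand for an effect only at larger amounts of compound and lower numbers for an effect already at smaller amounts:
- compound 1, `COc1ccccc1-c1cc(C2CCNC2)ccc1Cl`: 75.9 nM; 75 nM (2 entries)
- compound 2, `COc1ccccc1-c1cc(C2CCN(C)C2)ccc1Cl`: 646 nM; 650 nM (2 entries)
- compound 3, `CCCCNCc1ccc(Cl)c(-c2ccccc2OC)c1`: "not active" (no number reported), without a number

Compound 1 and compound 2 share a core, and their values show that compound 2 sits at a higher concentration than compound 1 the several entries of compound 1 in this assay, 75.9 nM; 75 nM (2 entries) (the several entries of compound 2 in this assay, 646 nM; 650 nM (2 entries)). Compound 3 carries the same core but an open chain amine instead, and in this assay compound 3 gave "not active" (no number reported), no measurable effect; two further entries for compound 3 also gave no number, so it stands only as inactive.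

Compound 4, `CCN(CC)Cc1ccc(Cl)c(-c2ccccc2OC)c1`, is built from the same atoms as compound 3, joined differently: diethylamino in place of butylamino on a saturated chain carbon bound to an aromatic carbon. Among the measured compounds shown here, no measured pair shows this exact change, so the step from compound 3 to compound 4 cannot be read off a number. Starting from a compound with no detectable activity, there is no basis for expecting a return to potency, and the estimate for compound 4 is 20000 nM, expected within 3000 nM to 100000 nM, with a real chance that only a limit is reported.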

Compound 4, half-maximal effective concentration: "not active" (no number reported)
The entry for compound 4 holds no number, and the estimate cannot be compared.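

Among the compounds shown here, compound 3 and compound 4 both gave no number, so no step between them can be read, and none of the other measured values bears on this result. Going by these compounds, whether an open chain amine on this shared core can reach a measurable effect stays open.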